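Swapping the methoxyphenyl of compound 3 for a dimethylphenyl

The source may hold more compounds than are shown below. What is called first, only, known or untested is meant among the compounds shown, and "the series" means these compounds.

The shared core carries a benzyl group on the ring nitrogen, varied across three measured compounds. In a functional assay on K562 cells (Homo sapiens) for cytotoxicity, read by MTT assay, with a stated time of 48 h (a higher number here means a weaker inhibitor, a lower number a stronger inhibitor), compound 1 `COC(=O)/C=C/c1ccc2c(c1)C(=O)C(=O)N2Cc1ccc(C)cc1` gives 40 nM, compound 2 `COC(=O)/C=C/c1ccc2c(c1)C(=O)C(=O)N2Cc1ccc(Cl)c(Cl)c1` gives 60 nM, and compound 3 `COC(=O)/C=C/c1ccc2c(c1)C(=O)C(=O)N2Cc1ccc(OC)cc1` gives 3 nM, the lowest of the three. Compound 4 `COC(=O)/C=C/c1ccc2c(c1)C(=O)C(=O)N2Cc1cc(C)cc(C)c1` is not yet measured; it differs from compound 3 by 3,5-dimethylphenyl in place of 4-methoxyphenyl on a saturated chain carbon bound to an amide-type nitrogen in a ring. The relevant steps run the other way: a 13-fold lower number from compound 1 to compound 3 (1.12 log units; beyond the scatter), and a 20-fold lower number from compound 2 to compound 3 (1.30 log units; beyond the scatter). Compound 4 carries no methoxy, like compound 1, so a step back upward toward the value of compound 1 is expected, namely a 10-fold higher number from compound 3 to compound 4 (1.00 log units; beyond the scatter). In this assay compound 4 is estimated at 30 nM, in the range 8 nM to 120 nM.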

Compound 4, half-maximal inhibitory concentration: 40 nM
The estimate for compound 4 lay 1.3-fold (0.12 log units) below the measured number; measured number inside the range.
By their numbers in this assay, from the lowest: compound 3; then compounds 1, 4 and 2 (each within the scatter of the next).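

In this assay, a 13-fold higher number from compound 3 to compound 4 (1.12 log units; beyond the scatter) shows that a second group without methoxy, 3,5-dimethylphenyl, also fails to match 4-methoxyphenyl on this saturated chain carbon, leaving compound 3 apart from all three others. Among those others, the new group brings no separation: there is no change at the digits printed from compound 1 to compound 4 (within the scatter) and a 1.5-fold lower number from compound 2 to compound 4 (0.18 log units; within the scatter). No measurement here accounts for the distinct result of compound 3. The compounds shown leave open whether an ethoxy group, a hydroxyl group or an amine in place of the methoxy of compound 3 would keep its low number.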